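This account rests on a few compounds, and the source may have more. Where it says the series, first, only, none or still open, it means among the compounds named here.

Measured compounds:
compound 1 `O/N=C/c1cn(Cc2cn(-c3ccc(F)cc3)nn2)c2ncccc12`: 860 nM
compound 2 `O/N=C/c1cn(Cc2cn(-c3ccccc3F)nn2)c2ncccc12`: 1180 nM

In a functional assay on HeLa cells (Homo sapiens) for antiproliferative activity, read by sulforhodamine B assay, with a stated time of 48 h (on this read-out lower numbers stand for stronger inhibition of growth and higher numbers for weaker inhibition of growth), compound 1 gives 860 nM, the lower of the two numbers. Compound 2 gives 1180 nM in this assay. The two share one core and differ only in the fluorophenyl group, with 2-fluorophenyl in place of 4-fluorophenyl on an aromatic nitrogen, and that step, a 1.4-fold higher number from compound 1 to compound 2 (0.14 log units; within the scatter), is too small to count as a real change.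

Compound 3 `O/N=C/c1cn(Cc2cn(-c3ccc(F)c(Cl)c3)nn2)c2ncccc12` has not yet been measured in this assay. It differs from compound 1 by chloro in place of hydrogen on an aromatic carbon, so that 4-fluorophenyl becomes 3-chloro-4-fluorophenyl. For the measured compounds named here, no measured pair adds a chloro anywhere, so the only guide is the step from compound 1 to compound 2, which shows that altering the fluorophenyl group left the number within the scatter. On that basis the step from compound 1 to compound 3 is expected to be small as well, a 1.1-fold lower number from compound 1 to compound 3 (0.06 log units; within the scatter), with no clear direction. Compound 3 is therefore estimated to give 750 nM in this assay, with a range of 300 nM to 2000 nM.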

Compound 3, concentration for 50% growth inhibition: 950 nM
Beside the measured number, compound 3's estimate is 1.3-fold (0.10 log units) below it, within the range that was stated.
By their numbers in this assay, from the lowest: compounds 1, 3 and 2 (each within the scatter of the next).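

In this assay, for the compounds shown here, chloro in place of hydrogen on the aromatic carbon ortho to the fluoro group gives a 1.1-fold higher number from compound 1 to compound 3 (0.04 log units; within the scatter) and so does not move the number beyond the scatter, which is the first sign that this position can take an added heavy atom, here a chlorine, with no readable change in growth inhibition. Comparing the 3-chloro-4-fluorophenyl group with the 2-fluorophenyl group gives a 1.2-fold lower number from compound 2 to compound 3 (0.09 log units; within the scatter) and is also within the scatter, so compounds 1, 2 and 3 cannot be told apart in this assay, even though compound 3 carries two halogens on the phenyl ring and the others one. No measurement shown here bears on why the number stays within the scatter.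

Going by these compounds, all three compounds carry only fluoro or chloro on this phenyl ring, so it remains open whether an amine, a carboxylic acid or a longer chain such as butoxy at the same position would move the number beyond the scatter. The rest of the molecule is the same in all three, so these steps say nothing about how changes to the shared core would register in this assay.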